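A few compounds are considered here, and "the series" means these few. Any claim that something is new, unique, unknown or untested is made for them only; others in the source may bear on it.

Measured so far in a physicochemical assay for acid dissociation:
compound 1 `CN(Cc1ccc(Cl)cc1)Cc1ccccc1CNc1ccnc2cc(Cl)ccc12`: 7.44
compound 2 `CN(Cc1ccc(N(C)C)cc1)Cc1cccc(CNc2ccnc3cc(Cl)ccc23)c1`: 7.36
compound 3 `CN(Cc1ccc(N(C)C)cc1)Cc1ccccc1CNc1ccnc2cc(Cl)ccc12`: 7.4

In this assay compound 2 gives 7.36, and this lies within the usual scatter of both other numbers, so the three compounds cannot be told apart here. The next to be measured is compound 4 `CN(Cc1ccc(Cl)cc1)Cc1cccc(CNc2ccnc3cc(Cl)ccc23)c1`, which differs from compound 2 in one place: chloro in place of dimethylamino on an aromatic carbon. In words, 4-(dimethylamino)benzyl becomes 4-chlorobenzyl.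

Going by the values given here, only one measured step bears on this change. It is the same swap run the other way, dimethylamino in place of chloro, and it gave a number 0.04 log units lower from compound 1 to compound 3 (within the scatter). That step sits on a different parent, so it is a guide and not a proof. Run in reverse, it suggests almost no movement. The expected result is a number 0.04 log units higher from compound 2 to compound 4 (within the scatter), which is no shift beyond the scatter. Compound 4 is estimated at 7.4, with an expected range from 7.15 to 7.65.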

Compound 4, acid dissociation constant: 7.55
For compound 4 the middle estimate is 0.15 log units below the measured one, within the range that was stated.
By their numbers in this assay, from the lowest: compounds 2, 3, 1 and 4 (each within the scatter of the next).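

In this assay, putting chloro in place of dimethylamino on this aromatic carbon, so that 4-(dimethylamino)benzyl becomes 4-chlorobenzyl, gives a number 0.19 log units higher from compound 2 to compound 4 (within the scatter) on the parent of compound 2. The same swap run the other way on a different parent gives a number 0.04 log units lower from compound 1 to compound 3 (within the scatter) so the change has now been read on two parents, and neither step lies beyond the scatter. No measurement bears on why the numbers sit where they do.

On these data alone, whether a different group on that aromatic carbon, such as a carboxylic acid or a methoxy group, would shift the number beyond the scatter remains open. Going by these compounds alone, only two groups appear at this place, so these four compounds support no wider pattern.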